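The source may hold more compounds than are shown below. What is called first, only, known or untested is meant among the compounds shown, and "the series" means these compounds.

Measured so far in a physicochemical assay for lipophilicity, read by HPLC, at pH 7.5; a higher number here means a more lipophilic compound, a lower number a more polar compound:
compound 1 `CCOc1ccccc1-c1ccc(-c2nc(NC(C)C(=O)O)c3ccncc3n2)cc1` — 2.1
compound 2 `CCOc1ccccc1-c1ccc(-c2nc3cnccc3c(NC(C(N)=O)C3CC3)c2C#N)cc1` — 3
compound 3 `CCOc1ccccc1-c1ccc(-c2nc3cnccc3c(N[C@H](CC)C(=O)NS(=O)(=O)C3CC3)c2C#N)cc1` — 2.3

Compound 2 stands highest of the three values. Compound 3 is nearest to it, a number 0.70 log units lower from compound 2 to compound 3 (beyond the scatter); compound 1 is furthest, its value lower still and beyond the scatter, but compound 1 differs from compound 2 in more than one place, so its value is shown without a step.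

Compound 4 `CCOc1ccccc1-c1ccc(-c2nc3cnccc3cc2C#N)cc1` has not yet been measured in this assay. Against compound 2 the change is: a hydrogen atom in place of a group of 8 heavy atoms (5 carbon, 2 nitrogen, 1 oxygen; one three-membered non-aromatic ring of carbon only), on an aromatic carbon

Within the data shown here, only one measured step exists for this series, a number 0.70 log units lower from compound 2 to compound 3 (beyond the scatter), and it exchanges one group for another on the nitrogen rather than removing the whole group from the aromatic carbon. Among the measured compounds shown here, no measured step therefore matches the change to compound 4 directly, and the expectation rests on the structural change alone. Removal of a group carrying two hydrogen-bond donors and two hydrogen-bond acceptors is expected to move the number upward by a modest amount, a number 0.40 log units higher from compound 2 to compound 4 (beyond the scatter). Compound 4 is estimated at 3.4, with a range of 2.8 to 4.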

Compound 4, distribution coefficient: 3.8
For compound 4 the middle estimate is 0.40 log units below the measured one; the range from low to high includes it.
By their numbers in this assay, from the lowest: compounds 1 and 3 (each within the scatter of the next); then compound 2; then compound 4.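

In this assay, taking the whole group of 8 heavy atoms off the aromatic carbon ortho to a cyano group, leaving hydrogen, gives a number 0.80 log units higher from compound 2 to compound 4 (beyond the scatter). Among these compounds, this is the first measured removal at this carbon, and it runs opposite in direction to the earlier exchange for a larger group, a number 0.70 log units lower from compound 2 to compound 3 (beyond the scatter), so compound 2 lies between compound 3 and compound 4 on this read-out. No measurement shown here accounts for the size of this step.

From the compounds shown here alone, whether a small group at this carbon, such as a methyl or a simple amine, would give a number nearer compound 4 or nearer compound 2 remains open. The compounds shown also do not separate the part played by the three-membered ring from that of the rest of the group.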